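The source may report more compounds than this note shows. Statements on the series, on what has been measured and on what is new or still open speak of the compounds shown alone.

Compound 2, `COc1ccccc1-c1nnc(-c2sc(-c3cccnc3)nc2C)o1`, has been tested in an ADME assay on PANC-1 cells (Homo sapiens) for cytotoxicity, read by MTT assay; on this read-out higher numbers stand for lower toxicity in this test and lower numbers for higher toxicity in this test. There compound 2 gives > 100 ug/mL, which is a limit of the assay rather than a number. Among the compounds with values here, compound 1, `Cc1nc(-c2cccnc2)sc1-c1nnc(-c2ccc(Br)cc2)o1`, is the only other compound with a reading in this assay. In that test compound 1 gives > 100 ug/mL, again a limit. Because both readings sit at the limit of > 100 ug/mL in this assay, at which 2 of the 2 values shown sit, the step that the two limits leave unreadable from compound 1 to compound 2 cannot be read. Compound 3, `Cc1nc(-c2cccnc2)sc1-c1nnc(-c2ccccc2[N+](=O)[O-])o1`, is not yet measured; it differs from compound 2 by nitro in place of methoxy on an aromatic carbon. Within the data shown here, no measured step involves a nitro in place of methoxy, and the single step on record is unreadable, so nothing shows how large a change in this assay to expect, nor in which direction. With both known readings at the limit, compound 3 is expected to stay close to it, and the expected step is a step that the limit leaves unreadable from compound 2 to compound 3. Compound 3 is therefore estimated at 120 ug/mL, with a range from 50 ug/mL to 300 ug/mL.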

Compound 3, half-maximal cytotoxic concentration: > 100 ug/mL
Compound 3: a limit, no number; the forecaster's own chance of this, stated with the estimate: 65%; the middle value does not contradict the limit.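

No step can be read from compound 2 to compound 3, because both readings are limits and not numbers: the limit of > 100 ug/mL in this assay, at which 3 of the 3 values shown sit. The compounds shown leave open whether nitro in place of methoxy changes anything in this assay, and at what concentration any of these compounds would become toxic.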